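The source may report more compounds than this note shows. Statements on the series, on what has been measured and on what is new or still open speak of the compounds shown alone.

In an assay on isolated protein for inhibition of malate dehydrogenase, mitochondrial (Sus scrofa), with stated times of 45 min and 30 min (a higher number here means a weaker inhibitor, a lower number a stronger inhibitor), three sulfonamides have been tested so far, and none of them gave a number. Compound 2 `O=S(=O)(Nc1ccc2oc(-c3ccccc3)nc2c1)c1cccc(C(F)(F)F)c1` reaches only the limit of the assay, > 63000 nM. Compound 1 `O=S(=O)(Nc1ccc2oc(-c3ccccc3)nc2c1)c1ccc(Cl)c(Cl)c1` likewise stops at the limit, > 63000 nM. Compound 3 `Cc1cccc(S(=O)(=O)Nc2ccc(-c3nc4ccccc4o3)cc2)c1` also ends at the limit, > 63000 nM. Where compound 2 stands can thus be told only roughly: it sits at the limit of > 63000 nM in this assay, at which 3 of the 3 values shown sit, together with every other value so far.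

Compound 4 `O=S(=O)(Nc1ccc2oc(-c3ccccc3)nc2c1)c1ccc(Cl)c(C(F)(F)F)c1` is the next to be measured in this assay. It differs from compound 2 in one place: chloro in place of hydrogen on an aromatic carbon. Among the compounds with values here, no two measured compounds differ in a single place; there is thus no measured step that shows what such a change does here. Within the data shown here, with every value so far at the limit, the expected step is a step that the limit leaves unreadable from compound 2 to compound 4, no change beyond the scatter. Compound 4 is therefore expected to give about 100000 nM in this assay, in the range 30000 nM to 300000 nM, most likely again reported only as a limit.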

Compound 4, half-maximal inhibitory concentration: > 63000 nM
Compound 4: only a limit was reported; the forecaster's own chance of this, stated with the estimate: 80%; the middle value is on the limit's open side.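

In this assay compound 4 gives only a limit, > 63000 nM. Its steps from compound 1 and from compound 2 therefore cannot be read: the limit of > 63000 nM in this assay, at which 4 of the 4 values shown sit. The compounds shown leave open whether any change to these sulfonamides alters inhibition in this assay.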